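The source may hold more compounds than are shown below. What is called first, only, known or untested is meant among the compounds shown, and "the series" means these compounds.

Compound 1 `O=C(Nc1cc(-c2ccccc2)[nH]n1)c1cccnc1F`: 14600 nM
Compound 2 `O=C(Nc1cc(-c2ccccc2)[nH]n1)c1ccc(Br)nc1`: 19400 nM

In a functional assay on WM1361 cells (Homo sapiens) for antiproliferative activity, read by MTT assay, with a stated time of 48 h (a higher number here means a weaker inhibitor, a lower number a stronger inhibitor), compound 1 gives 14600 nM and sits within the scatter of compound 2, so neither can be ranked above the other. Compound 3 `O=C(Nc1cc(-c2ccc(Br)cc2)[nH]n1)c1cccnc1F` keeps the core of compound 1 but turns phenyl into 4-bromophenyl: bromo in place of hydrogen on an aromatic carbon. The bromo replaces a hydrogen on an aromatic carbon, para to a large group.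

Among the compounds with values here, only one measured step is available, a 1.3-fold higher number from compound 1 to compound 2 (0.12 log units; within the scatter). It swaps 2-fluoropyridin-3-yl for 6-bromopyridin-3-yl on a carbonyl carbon, so it bears on the new change only indirectly. Within the data shown here, no measured pair tests a change on the phenyl itself. A step beyond the scatter in this assay is therefore not expected, in either direction. Compound 3 is estimated at 13000 nM, with an expected range from 5000 nM to 32000 nM. The estimate means an expected 1.1-fold lower number from compound 1 to compound 3 (0.05 log units; within the scatter).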

Compound 3, half-maximal inhibitory concentration: 15700 nM
Estimate against measurement, compound 3: 1.2-fold (0.08 log units) below; the measured number falls inside the stated range.
By their numbers in this assay, from the lowest: compounds 1, 3 and 2 (each within the scatter of the next).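

Within the data shown here, the earlier compounds differed only in the group on the carbonyl carbon, so compound 3 gives the first measured look at the phenyl on the other side of the molecule. In this assay, among these compounds, adding a bromo para to a large group gives a 1.1-fold higher number from compound 1 to compound 3 (0.03 log units; within the scatter), so this single heavy atom on the aromatic carbon produces no step that can be told apart from the scatter, and compound 3 cannot be ranked against compound 1. No measurement on hand offers a reason for this result.

The compounds shown leave open whether a different group at this place, such as an amine, a carboxylic acid or a longer chain, would give a step beyond the scatter. They also leave open whether the bromo would read the same with the 6-bromopyridin-3-yl of compound 2 on the carbonyl carbon.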